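Adding a dimethylcarbamoyl group to compound 3

The source may hold more compounds than are shown below. What is called first, only, known or untested is meant among the compounds shown, and "the series" means these compounds.

Three compounds share one core and differ only in the group attached to an aromatic carbon. In an ADME assay on microsomes from liver (Homo sapiens) for metabolic stability, read by LC-MS, using NADPH, with stated times of 5 min and 30 min, tested at 1 uM (on this read-out lower numbers stand for slow clearance and higher numbers for fast clearance), compound 1 `Cn1nccc1-c1cnc(NCc2c(F)ccc3c2CCO3)c2cn[nH]c(=O)c12` gives 14 mL.min-1.g-1 as its number, compound 2 `CC(=O)N1CCC(c2cnc(NCc3c(F)ccc4c3CCO4)c3cn[nH]c(=O)c23)CC1` gives 207 mL.min-1.g-1 and compound 3 `Cc1ncccc1-c1cnc(NCc2c(F)ccc3c2CCO3)c2cn[nH]c(=O)c12` gives 41 mL.min-1.g-1 on the same scale, which makes compound 3 the second highest of the three.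

Compound 4 `Cc1nc(C(=O)N(C)C)ccc1-c1cnc(NCc2c(F)ccc3c2CCO3)c2cn[nH]c(=O)c12` differs from compound 3 by one addition, a dimethylcarbamoyl group in place of hydrogen (dimethylcarbamoyl in place of hydrogen on an aromatic carbon), on an aromatic carbon next to the ring nitrogen.

The measured steps give a sense of scale: a 15-fold higher number from compound 1 to compound 2 (1.17 log units; beyond the scatter) is large, while a 2.9-fold higher number from compound 1 to compound 3 (0.47 log units; beyond the scatter) and a 5.0-fold lower number from compound 2 to compound 3 (0.70 log units; beyond the scatter) are modest. Each of them swaps the whole group, and none adds a substituent to a ring that stays, so they show no direction for this change. No step beyond the scatter is therefore expected, and the estimated move is a 1.0-fold lower number from compound 3 to compound 4 (0.01 log units; within the scatter) in this assay on this evidence. For compound 4 the estimated value is 40 mL.min-1.g-1 (expected range 15 mL.min-1.g-1 to 110 mL.min-1.g-1).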

Compound 4, intrinsic clearance in microsomes: 19 mL.min-1.g-1
Compound 4: middle estimate off by 2.1-fold (0.32 log units), on the high side; the measured number falls inside the stated range.
By their numbers in this assay, from the lowest: compounds 1 and 4 (each within the scatter of the next); then compound 3; then compound 2.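

Among the compounds shown here, compound 4 is the first case here in which a group is added to a ring that stays rather than the whole group being swapped, and in this assay the result is a 2.2-fold lower number from compound 3 to compound 4 (0.33 log units; beyond the scatter). So this aromatic carbon next to the ring nitrogen can carry a dimethylcarbamoyl group, with its 5 heavy atoms, and the number still moves modestly towards slower clearance rather than faster. No measurement shown here explains why adding this group lowers the number.

Going by these compounds, it remains open whether a smaller primary amide, a nitrile or a carboxylic acid on the same carbon would move the number in the same direction. On these data alone, it is also open whether the dimethylcarbamoyl group would have a similar effect on another carbon of this ring.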